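The compounds below may be only part of what the source reports. "The series", "measured", "known", "first", "only" and "open" are said of these compounds alone.

Within the data shown here, compound 1, with structure `O=C(CCc1ccccc1)Nc1nc2ccccc2c(=O)s1`, is the only member of the series with a numerical reading: in an assay on membranes from brain for displacement of a labelled ligand from adenosine receptor A1 (Rattus norvegicus), read by scintillation counting, with a stated time of 90 min (on this read-out higher numbers stand for weaker inhibition and lower numbers for stronger inhibition), compound 1 gives 422 nM. Compound 2, structure `Cc1sc2nc(NC(=O)CCCc3ccccc3)sc(=O)c2c1C`, carries a different core and in this assay reaches only the limit of > 10000 nM, which is a limit and not a number; this is the point described by the limit of > 10000 nM in this assay, at which 1 of the 2 values shown sits. Among the measured compounds shown here, no step between two measured compounds is available, so compound 2 offers no measured comparison for the chain change.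

Compound 3, structure `O=C(CCCc1ccccc1)Nc1nc2ccccc2c(=O)s1`, keeps the core of compound 1 and differs by benzyl in place of phenyl on a saturated chain carbon, two bonds along the chain from a carbonyl carbon. The expected step from compound 1 is a 1.9-fold higher number from compound 1 to compound 3 (0.28 log units; within the scatter), a modest move toward weaker inhibition, though one that could fall within the scatter. On that basis compound 3 is estimated at 800 nM in this assay, with a likely range from 250 nM to 3000 nM.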

Compound 3, inhibition constant: 229 nM
The estimate for compound 3 lay 3.5-fold (0.54 log units) above the measured number, and the stated range ends above it.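

In this assay, benzyl in place of phenyl on a saturated chain carbon, two bonds along the chain from a carbonyl carbon, gives a 1.8-fold lower number from compound 1 to compound 3 (0.27 log units; within the scatter). Among these compounds, this is the first measured step at this position, and it shows that the shared core tolerates the extra carbon of benzyl with no difference that can be told from the scatter, so compound 1 and compound 3 read as equivalent for now. No measurement shown accounts for this step.

Still open, on these data alone, is whether a longer chain, with more carbons than benzyl, would stay level with these two compounds on the shared core or would separate from them beyond the scatter. Also open, as far as these compounds go, is how an amine or a carboxylic acid in place of benzyl at this position would read in this assay.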